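Methyl in place of fluoro, tested on a second core

The source may report more compounds than this note shows. Statements on the series, on what has been measured and on what is new or still open speak of the compounds shown alone.

Compound 1 `Fc1ccc(-c2cc(/C=N/c3ccccc3)on2)cc1` gives 34500 nM in a functional assay on A549 cells (Homo sapiens) for inhibition, read by MTT assay, with a stated time of 24 h; on this read-out lower numbers stand for stronger inhibition and higher numbers for weaker inhibition. Compound 2 `Cc1ccc(-c2cc(/C=N/c3ccccc3)on2)cc1` gives 32000 nM in this assay. The change between them, (methyl in place of fluoro on an aromatic carbon), made a 1.1-fold lower number from compound 1 to compound 2 (0.03 log units; within the scatter). Compound 3 `CCc1cc2ccccc2nc1-c1cc(-c2ccc(F)cc2)no1` gives no number but a limit in this assay, > 100000 nM. This is the limit of > 100000 nM in this assay, at which 1 of the 3 values shown sits. How the core of compound 3 differs from the core of compound 1 is not broken down here. Compound 4 `CCc1cc2ccccc2nc1-c1cc(-c2ccc(C)cc2)no1` carries the same change on that core, (methyl in place of fluoro on an aromatic carbon); the two place descriptions match word for word, so it is the same change. Compound 4 is expected to give about 120000 nM, between 50000 nM and 300000 nM, with a high chance that only a limit is reported. The expected step, a step that the limit leaves unreadable from compound 3 to compound 4, rests on the earlier pair showing a 1.1-fold lower number from compound 1 to compound 2 (0.03 log units; within the scatter).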

Compound 4, half-maximal inhibitory concentration: > 100000 nM
Compound 4: no number, only a limit; the forecaster's own chance of this, stated with the estimate: 70%; the middle value is on the limit's open side.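

No step can be read from compound 3 to compound 4, since each gives only a limit and no number: the limit of > 100000 nM in this assay, at which 2 of the 4 values shown sit. On these data alone, whether methyl in place of fluoro alters the read-out on this second core remains open.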